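The source may hold more compounds than are shown below. What is called first, only, known or untested is meant among the compounds shown, and "the series" means these compounds.

Among the measured compounds shown here, compound 1 `C#CCOC(=O)Cn1cnc2c1c(=O)n(C)c(=O)n2C` is the smallest of the three compounds measured so far, and in a functional assay on A549 cells (Homo sapiens) for cytotoxicity, read by MTT assay, with a stated time of 48 h (a higher number here means a weaker inhibitor, a lower number a stronger inhibitor), compound 1 gives 156000 nM. That is the highest of the three numbers, so compound 1 is the weakest inhibitor in this group. Compound 2 `CCn1c(=O)ccn(C2OC(Cn3cc(COC(=O)C(C)NC(=O)C(C)n4cnc5c4c(=O)n(C)c(=O)n5C)nn3)C(O)C2O)c1=O` joins the same core through a linker to a much larger fragment; in this assay compound 2 gives 1560 nM. Compound 3 `CCn1c(=O)ccn(C2OC(Cn3cc(COC(=O)CNC(=O)Cn4cnc5c4c(=O)n(C)c(=O)n5C)nn3)C(O)C2O)c1=O` is built in the same way with a shorter linker, and compound 3 gives 3570 nM. Both lie far below compound 1, beyond the usual scatter, with compound 3 the nearer of the two.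

Compound 4 `C#CCCOC(=O)Cn1cnc2c1c(=O)n(C)c(=O)n2C` differs from compound 1 in one place: propargyl in place of ethynyl on a saturated chain carbon bound to an oxygen next to a carbonyl group. The chain grows from propargyl to but-3-yn-1-yl while the triple bond is kept. For the measured compounds named here, no measured pair here shows how such a change moves the number. The step is expected to be small and within the scatter, in either direction: a 1.0-fold lower number from compound 1 to compound 4 (0.02 log units; within the scatter). The estimate for compound 4 is 150000 nM, with a likely range from 60000 nM to 400000 nM.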

Compound 4, half-maximal inhibitory concentration: 104000 nM
Compound 4: the middle estimate sits 1.4-fold (0.16 log units) above what was measured, and the stated range covers the measured number.
By their numbers in this assay, from the lowest: compound 2; then compound 3; then compounds 4 and 1 (each within the scatter of the next).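

In this assay, the chain grows from propargyl to but-3-yn-1-yl with the triple bond kept, and this gives a 1.5-fold lower number from compound 1 to compound 4 (0.18 log units; within the scatter). Among the compounds shown here, this is the first measured pair that differs in one place, and its two numbers cannot be told apart. At this position on a saturated chain carbon bound to an oxygen next to a carbonyl group, the one extra carbon therefore leaves no readable mark on the cytotoxicity number. No measurement shown here offers an explanation for this result.

Only this one small change at the position is shown, so a single pair cannot say how far the chain can grow before the number moves. As far as these compounds go, whether a longer chain, or a chain ending in an amine or a carboxylic acid instead of the triple bond, would give a different number remains open.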